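Carboxy for methoxy on a chain already at the assay limit

The source may hold more compounds than are shown below. What is called first, only, known or untested is meant among the compounds shown, and "the series" means these compounds.

Compound 1 `O=C(O)CCNC(=O)c1ccc(CN(C(=O)Nc2ccc(OC(F)(F)F)cc2)C2CCC(C(=O)NCC3CC3)CC2)cc1`: > 10000 nM
Compound 2 `COCCCNC(=O)c1ccc(CN(C(=O)Nc2ccc(OC(F)(F)F)cc2)C2CCC(C(C)(C)C)CC2)cc1`: > 10000 nM

Of the compounds shown here, two share the core and have been measured in an in vitro assay on BHK cells for inhibition of Glucagon receptor (Homo sapiens); a lower number here means a stronger inhibitor, a higher number a weaker inhibitor. Compound 1, with its carboxy-bearing chain on an aminocyclohexyl bearing a cyclopropylmethyl amide, reaches only a limit of the assay, > 10000 nM. Compound 2, which carries a tert-butyl on the cyclohexyl and a methoxypropyl amide, likewise gives only a limit, > 10000 nM. Thus compound 2 stands at the upper boundary of what this assay reports, and the other value shown sits there too (the limit of > 10000 nM in this assay, at which 2 of the 2 values shown sit).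

Compound 3 `CC(C)(C)C1CCC(N(Cc2ccc(C(=O)NCCCC(=O)O)cc2)C(=O)Nc2ccc(OC(F)(F)F)cc2)CC1` differs from compound 2 by carboxy in place of methoxy on a saturated chain carbon, three bonds along the chain from an amide-type nitrogen. Among the compounds with values here, no measured step tells how large a change this brings. Since both anchors are limits, compound 3 is expected to remain near the limit, with the step from compound 2 to compound 3 estimated as a step that the limit leaves unreadable from compound 2 to compound 3. Compound 3 is estimated at 15000 nM, between 5000 nM and 50000 nM.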

Compound 3, half-maximal inhibitory concentration: > 10000 nM
Compound 3 ended at the assay's limit; the forecaster's own chance of this, stated with the estimate: 80%; the middle value is on the limit's open side.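

No step can be read from compound 2 to compound 3, since both stop at a limit: the limit of > 10000 nM in this assay, at which 3 of the 3 values shown sit. The compounds shown leave open whether carboxy in place of methoxy changes inhibition at all, and how strong any of the three is in this assay.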